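A Sulfur Link in Place of a Carbon Chain

This account rests on a few compounds, and the source may have more. Where it says the series, first, only, none or still open, it means among the compounds named here.

In an assay for inhibition of Polyunsaturated fatty acid 5-lipoxygenase (Homo sapiens), read by HPLC, with a stated time of 10 min (a lower number here means a stronger inhibitor, a higher number a weaker inhibitor), compound 3 `Cc1cccc(OCCCOc2ccc(CCC(=O)O)cc2)c1C` returns > 10000 nM, which is a limit of the assay rather than a number. Compound 1 `CCCCC(Sc1ccc(OCCCOc2ccc3ncccc3c2)cc1)C(=O)OCC` also stops at a limit, giving > 10000 nM. Compound 2 `CCCCC(Sc1ccc(OCCCOc2ccc(Cl)cc2OC)cc1)C(=O)O` likewise gives > 10000 nM, again a limit. Going by the values given here, all three share (the limit of > 10000 nM in this assay, at which 3 of the 3 values shown sit), so no step between measured compounds can be drawn from them. Compound 4 `Cc1cccc(OCCCOc2ccc(SCC(=O)O)cc2)c1C` differs from compound 3 in one place: (carboxymethyl)sulfanyl in place of 2-carboxyethyl on an aromatic carbon. With nothing but limits among the measured compounds, the step that the limit leaves unreadable from compound 3 to compound 4 is expected to be none beyond the scatter, most probably leaving compound 4 at the limit as well. Compound 4 is accordingly estimated at 15000 nM, within a range of 5000 nM to 50000 nM.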

Compound 4, half-maximal inhibitory concentration: > 10000 nM
Compound 4: a limit, no number (the forecaster's own chance of this, stated with the estimate: 80%); the middle value lies beyond the limit too.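

Going by these compounds alone, no step from compound 3 to compound 4 can be read, because both stop at a limit: the limit of > 10000 nM in this assay, at which 4 of the 4 values shown sit. The compounds shown leave open whether (carboxymethyl)sulfanyl in place of 2-carboxyethyl changes inhibition at all.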